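Compound 2 to compound 3: a carbonyl substituent swap

The source may hold more compounds than are shown below. What is called first, only, known or untested is meant among the compounds shown, and "the series" means these compounds.

Values in a physicochemical assay for solubility, measured as kinetic solubility, with a stated time of 1 h, at pH 7.4 (a higher number here means a more soluble compound, a lower number a less soluble compound), are:
compound 1 `N#CCCC(=O)NC1=NN(c2ccc(Cl)c(Cl)c2)CC1` gives 39000 nM
compound 2 `O=C1CCCC(C(=O)NC2=NN(c3ccc(Cl)c(Cl)c3)CC2)N1` gives 416000 nM

Compound 2 stands highest of the two, beyond the scatter. Compound 3 `O=C(NC1=NN(c2ccc(Cl)c(Cl)c2)CC1)c1cccnc1` carries pyridin-3-yl in place of 6-oxopiperidin-2-yl on a carbonyl carbon and is still unmeasured. Within the data shown here, one measured step bears on this, large and beyond the scatter (an 11-fold higher number from compound 1 to compound 2 (1.03 log units; beyond the scatter)). Among the measured compounds shown here, it brought in the group now leaving, so a step down of somewhat smaller size is expected in this assay, although no measured step has pyridin-3-yl entering. The estimated change is a 6.9-fold lower number from compound 2 to compound 3 (0.84 log units; beyond the scatter) as the working figure. Compound 3 is estimated at 60000 nM (expected range 15000 nM to 220000 nM).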

Compound 3, solubility: 4000 nM
Beside the measured number, compound 3's estimate is 15-fold (1.18 log units) above it; measured number outside the range, below it.
By their numbers in this assay, from the lowest: compound 3; then compound 1; then compound 2.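

On the carbonyl carbon, pyridin-3-yl gives the lowest number of the three groups in this assay, with a 100-fold lower number from compound 2 to compound 3 (2.02 log units; beyond the scatter) and a 9.8-fold lower number from compound 1 to compound 3 (0.99 log units; beyond the scatter), so this position moves the read-out in both directions from the 2-cyanoethyl compound. The change from compound 2 to compound 3 swaps a non-aromatic ring carrying a hydrogen-bond donor for an aromatic ring with none. Nothing available accounts for the size of this drop.

Ring type and donor change together here, so the compounds shown cannot separate them. As far as these compounds go, how a phenyl ring or a carboxylic acid would read at this carbonyl carbon remains open.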